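A few compounds are considered here, and "the series" means these few. Any claim that something is new, unique, unknown or untested is made for them only; others in the source may bear on it.

Measured so far:
compound 1, `COc1ccc(N2CCN(c3cc(C(F)(F)F)ccc3CNC(=O)C(C)c3ccc(NS(C)(=O)=O)c(F)c3)CC2)cc1`: 1.6 nM
compound 2, `CCCOc1cc(C(F)(F)F)ccc1CNC(=O)C(C)c1ccc(NS(C)(=O)=O)c(F)c1`: 2 nM

Going by the values given here, in an assay on CHO cells for antagonist activity at transient receptor potential cation channel subfamily V member 1 (Homo sapiens), read by FLIPR (a lower number here means a stronger inhibitor, a higher number a weaker inhibitor), compound 2 gives 2 nM, and its only neighbour on these numbers is compound 1 at 1.6 nM; the gap between the two lies within the usual scatter, so neither can be ranked against the other. Among the compounds with values here, no step between measured compounds differing in a single place is available, and the two measured compounds differ at several places at once.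

Compound 3, `CC(C(=O)NCc1ccc(C(F)(F)F)cc1SC1CCCC1)c1ccc(NS(C)(=O)=O)c(F)c1`, is not yet measured. Against compound 2 the change is cyclopentylsulfanyl in place of propoxy on an aromatic carbon. Both measured compounds carry groups of quite different size at this position and give indistinguishable numbers, so no step beyond the scatter is expected here; the step of a 1.1-fold higher number from compound 2 to compound 3 (0.04 log units; within the scatter) is estimated to be flat. Compound 3 is accordingly expected near 2.2 nM, with a range of 0.6 nM to 8 nM in this assay.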

Compound 3, inhibition constant: 0.3 nM
The estimate for compound 3 lay 7.3-fold (0.87 log units) above the measured number; the measured number lies below the stated range.
By their numbers in this assay, from the lowest: compound 3; then compounds 1 and 2 (each within the scatter of the next).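

Going by these compounds alone, at this aromatic carbon, meta to a trifluoromethyl group, the substituent does affect the number in this assay: cyclopentylsulfanyl in place of propoxy gives a 6.7-fold lower number from compound 2 to compound 3 (0.82 log units; beyond the scatter) and provides the first single-place comparison, showing that the position is not indifferent to the group it carries. The change replaces oxygen with sulfur and an open chain with a five-membered carbon ring in one step, so this pair cannot separate the two contributions. No measured evidence bears on the reason for the step.

Still open, on these data alone, is whether cyclopentyloxy or propylsulfanyl would keep the lower number, which would assign the step to the ring or to the sulfur. Also open, as far as these compounds go, is how an amine or a longer alkylsulfanyl chain at this carbon would read.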